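Cyclopropyl thio-group on the sugar arm of compound 3

This account rests on a few compounds, and the source may have more. Where it says the series, first, only, none or still open, it means among the compounds named here.

Going by the values given here, compound 3, with the structure `CC(C)NC(=O)OC[C@H]1OC(n2cnc3c(NC4CCOC4)ncnc32)[C@H](O)[C@@H]1O`, stands second highest of the three numbers so far in an assay on DDT1 cells (Cricetulus griseus) for binding affinity to adenosine receptor A1 (Homo sapiens), read by radioligand binding (a higher number here means a weaker inhibitor, a lower number a stronger inhibitor), where compound 3 gives 78 nM. Its nearest neighbour is compound 1, of structure `CCC/N=C(\S)OC[C@H]1OC(n2cnc3c(NC4CCOC4)ncnc32)[C@H](O)[C@@H]1O`, which in this assay gives 50 nM; the step of a 1.6-fold higher number from compound 1 to compound 3 (0.19 log units; within the scatter) is within the scatter. Compound 2, of structure `CCCC/N=C(\S)OC[C@H]1OC(n2cnc3c(NC4CCOC4)ncnc32)[C@H](O)[C@@H]1O`, gives 157 nM in this assay, and the step of a 2.0-fold lower number from compound 2 to compound 3 (0.30 log units; within the scatter) is also within the scatter. Among the compounds with values here, the one step beyond the scatter is a 3.1-fold higher number from compound 1 to compound 2 (0.50 log units; beyond the scatter).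

Compound 4, of structure `O[C@@H]1[C@@H](CO/C(S)=N/C2CC2)OC(n2cnc3c(NC4CCOC4)ncnc32)[C@@H]1O`, differs from compound 3 in one place: a group of 6 heavy atoms (4 carbon, 1 nitrogen, 1 sulfur; one three-membered non-aromatic ring of carbon only) in place of a group of 6 heavy atoms (4 carbon, 1 nitrogen, 1 oxygen; no ring), on an oxygen on a saturated carbon. The exchange of an oxygen-bearing for a sulfur-bearing group at this oxygen has already been seen between compound 3 and compound 1, and cost little. The cyclopropyl group of compound 4 is of the same atom count as the isopropyl it replaces, so a small step is expected, a 1.3-fold lower number from compound 3 to compound 4 (0.11 log units; within the scatter), and compound 4 is estimated in this assay at 60 nM, within the range 25 nM to 150 nM.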

Compound 4, inhibition constant: 157 nM
Estimate against measurement, compound 4: 2.6-fold (0.42 log units) below, and the stated range ends below it.
By their numbers in this assay, from the lowest: compounds 1, 3, 2 and 4 (each within the scatter of the next, the first and the last beyond it).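

In this assay the step from propyl to cyclopropyl on the double-bonded nitrogen is not neutral, since a 3.1-fold higher number from compound 1 to compound 4 (0.50 log units; beyond the scatter) matches in size the step to the longer butyl chain, a 3.1-fold higher number from compound 1 to compound 2 (0.50 log units; beyond the scatter) and so among these three groups propyl alone gives the lower number. Cyclopropyl and butyl cannot be told apart at this position, with no change at the digits printed from compound 2 to compound 4 (within the scatter) as the printed result, and the step against the isopropylcarbamoyl group, a 2.0-fold higher number from compound 3 to compound 4 (0.30 log units; within the scatter) separates nothing either. The data shown hold no measurement that accounts for the step away from propyl.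

From the compounds shown here alone, whether propyl also stays ahead of an ethyl or a cyclobutyl group on the double-bonded nitrogen remains open. So does how a cyclopropyl carbamoyl group, with oxygen in place of the sulfur, would compare with compound 4 in this assay at this oxygen.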